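The compounds below may be only part of what the source reports. "The series", "measured", "known", "first", "only" and "open" are said of these compounds alone.

Measured so far:
- compound 1 `COc1ccc(/C=C/C(=O)Nc2cc(C(=O)c3cc(OC)c(OC)c(OC)c3)cc(OC)c2OC)cc1OC`; in a functional assay on B16 cells (Mus musculus) for cytotoxicity, read by MTT assay, with a stated time of 72 h (on this read-out lower numbers stand for stronger inhibition and higher numbers for weaker inhibition), compound 1 gives 1300 nM
- compound 2 `COc1cccc(/C=C/C(=O)Nc2cc(C(=O)c3cc(OC)c(OC)c(OC)c3)cc(OC)c2OC)c1`; in this assay compound 2 gives 6700 nM

Among the compounds with values here, compound 2 holds the higher of the two numbers in this assay, weaker than compound 1 by a 5.2-fold higher number from compound 1 to compound 2 (0.71 log units; beyond the scatter), the only measured step. Compound 3 `COc1ccc(/C=C/C(=O)Nc2cc(C(=O)c3cc(OC)c(OC)c(OC)c3)cc(OC)c2OC)cc1N` is not yet measured. It differs from compound 2 by 3-amino-4-methoxyphenyl in place of 3-methoxyphenyl on a double-bonded chain carbon bound to a double-bonded chain carbon; cut one bond further out this reads 2-(3-methoxyphenyl)ethenyl to 2-(3-amino-4-methoxyphenyl)ethenyl. Within the data shown here, the one measured step bears on it directly, since compound 3 restores the methoxy whose removal cost a 5.2-fold higher number from compound 1 to compound 2 (0.71 log units; beyond the scatter), and then carries an amino group where compound 1 carries methoxy. Among the measured compounds shown here, no measured step covers that amino-for-methoxy exchange. The expectation for compound 3 is therefore a drop of roughly the size seen between compound 1 and compound 2, reversed, as an 8.4-fold lower number from compound 2 to compound 3 (0.92 log units; beyond the scatter). Compound 3 is thus estimated at 800 nM, with a range from 250 nM to 3000 nM.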

Compound 3, half-maximal inhibitory concentration: 12700 nM
Compound 3: middle estimate off by 16-fold (1.20 log units), on the low side; measured number above the stated range.
By their numbers in this assay, from the lowest: compound 1; then compounds 2 and 3 (each within the scatter of the next).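

In the series, the methoxy of compound 1 cannot be exchanged for amino at this place without loss in this assay: amino in place of methoxy on an aromatic carbon gives (a 9.8-fold higher number from compound 1 to compound 3 (0.99 log units; beyond the scatter)). The 3-amino-4-methoxyphenyl group also recovers none of the gap between compound 2 and compound 1, since replacing 3-methoxyphenyl with it gives (a 1.9-fold higher number from compound 2 to compound 3 (0.28 log units; within the scatter)), and the methoxy added alongside the amino group therefore brings no visible gain on this read-out. No supporting data bear on why this exchange behaves as it does.

Open, going by these compounds, is whether a hydroxyl or an acetamide in place of the amino group of compound 3 would stand nearer to compound 1 or to compound 3. Also open, on these data alone, is whether a fluorine there would hold the number of compound 1.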